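The source may report more compounds than this note shows. Statements on the series, on what has been measured and on what is new or still open speak of the compounds shown alone.

Of the compounds shown here, three have been measured in a functional assay on HepG2 cells (Homo sapiens) for antiproliferative activity, read by MTT assay, with a stated time of 48 h; on this read-out higher numbers stand for weaker inhibition and lower numbers for stronger inhibition. Compound 1 `Cc1ccc(-c2nc(NO)c3cc(Cl)ccc3n2)cc1` gives 23.1 ug/mL, the highest of the three numbers. Compound 2 `Cc1ccc(-c2nc3ccc(Cl)cc3c(=S)o2)cc1` gives 11.1 ug/mL in this assay, and compound 3 `Cc1ccc(C(=O)Nc2ccc(Cl)cc2C(=S)NN)cc1` gives 5.59 ug/mL, so compound 1 sits at the weak end of what has been seen. Compound 4 `Cc1ccc(-c2nc(SCC#N)c3cc(Cl)ccc3n2)cc1` has not been measured; it differs from compound 1 by one change: (cyanomethyl)sulfanyl in place of hydroxyamino on an aromatic carbon. Within the data shown here, no measured pair shows this change, so there is no direct precedent for its size. A modest step toward a lower number is expected, though one that need not exceed the scatter. The estimate for compound 4 is 15 ug/mL, with a range from 4 ug/mL to 50 ug/mL, which means an expected step of a 1.5-fold lower number from compound 1 to compound 4 (0.19 log units; within the scatter).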

Compound 4, half-maximal inhibitory concentration: 4.37 ug/mL
Compound 4: the middle estimate sits 3.4-fold (0.54 log units) above what was measured; low and high end bracket the measured number.
By their numbers in this assay, from the lowest: compounds 4, 3 and 2 (each within the scatter of the next, the first and the last beyond it); then compound 1.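

Placing (cyanomethyl)sulfanyl in place of hydroxyamino on this aromatic carbon, next to the ring nitrogen, gives a 5.3-fold lower number from compound 1 to compound 4 (0.72 log units; beyond the scatter) in this assay, so the read-out responds to the group at this position. The entering group has no hydrogen-bond donors, so donors at this place are not required for the lower number. No measurement available here accounts for the size of this step. As far as these compounds go, whether the sulfur or the nitrile carries the step stays open. From the compounds shown here alone, how a plain amine or a methylsulfanyl group would read at this place also stays open.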